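Working notes on the shared urea core, ring exchange

The compounds below may be only part of what the source reports. "The series", "measured", "known", "first", "only" and "open" are said of these compounds alone.

The shared core carries three variants so far: compound 1 is `O=C(Nc1ccc(-n2ncc3c(C(F)(F)F)cccc32)cc1)Nc1ccc(Cl)c(C(F)(F)F)c1`, compound 2 is `O=C(Nc1ccc(-n2ncc3c(Br)cccc32)cc1)Nc1ccc(Cl)c(C(F)(F)F)c1`, and compound 3 is `Cc1cccc2c1cnn2-c1ccc(NC(=O)Nc2ccc(Cl)c(C(F)(F)F)c2)cc1`. In a functional assay on OS-RC-2 cells (Homo sapiens) for cytotoxicity, read by MTT assay, with a stated time of 72 h (on this read-out lower numbers stand for stronger inhibition and higher numbers for weaker inhibition), compound 1 gives only a limit, > 32000 nM. Compound 2 gives 9900 nM. Compound 3 gives 32000 nM, the highest of the two real numbers; its nearest neighbour is compound 2, with a 3.2-fold higher number from compound 2 to compound 3 (0.51 log units; beyond the scatter). Compound 4, `O=C(Nc1ccc(-n2ncc3ccncc32)cc1)Nc1ccc(Cl)c(C(F)(F)F)c1`, differs from compound 3 by a group of 9 heavy atoms (6 carbon, 3 nitrogen; one five-membered aromatic ring with 2 hetero atoms, one six-membered aromatic ring with 1 hetero atom) in place of a group of 10 heavy atoms (8 carbon, 2 nitrogen; one five-membered aromatic ring with 2 hetero atoms, one six-membered aromatic ring of carbon only), on an aromatic carbon. For the measured compounds named here, the measured steps, an at least 3.2-fold lower number from compound 1 to compound 2 (0.50 log units; beyond the scatter) and a number no higher from compound 1 to compound 3 (the limit leaves the size open), each exchange one substituent and do not read on an exchange of the whole bicyclic group, so no step bears on this change. The expected step is therefore a 1.6-fold lower number from compound 3 to compound 4 (0.20 log units; within the scatter), within the scatter, with wide uncertainty. Compound 4 is estimated at 20000 nM, in the range 5000 nM to 60000 nM.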

Compound 4, half-maximal inhibitory concentration: > 32000 nM
Compound 4 gave a limit, no number; the forecaster's own chance of this, stated with the estimate: 40%; at least 1.6-fold (0.20 log units) between middle value and limit.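

In this assay, exchanging the whole bicyclic group on an aromatic carbon para to a large group gives an at least 3.2-fold higher number from compound 2 to compound 4 (0.50 log units; beyond the scatter), so the entering group, with a hetero atom in its six-membered ring, does not match compound 2. The same exchange also gives a number no lower from compound 3 to compound 4 (the limit leaves the size open) and the size of this step cannot be read. Compound 4 gives a limit and not a number, the same limit that compound 1 gives: the limit of > 32000 nM in this assay, at which 2 of the 4 values shown sit.

Open, as far as these compounds go, is whether this entering group would behave differently if it carried a bromo group. Also open, from the compounds shown here alone, is whether a chloro or methoxy group in place of bromo would stay level with compound 2.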